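The source may report more compounds than this note shows. Statements on the series, on what has been measured and on what is new or still open speak of the compounds shown alone.

Compound 2 `COc1cccc(-n2cc3nc(-c4ccccc4C)n(CC4CCCN(C(C)C)C4)c(=O)c3n2)c1` gives 10 in a physicochemical assay for acid dissociation, level with compound 1 `COc1ccc(-n2cc3nc(-c4ccccc4C)n(CC4CCCN(C(C)C)C4)c(=O)c3n2)cc1`, which gives 10; together these two stand highest of the three measured numbers. Among the measured compounds shown here, compound 3 `Cc1ncccc1-c1nc2cn(-c3ccc(C#N)cc3)nc2c(=O)n1CC1CCCN(C2COC2)C1` gives 6.4, a number far below them, but no single-place step links compound 3 to either of the others. For the measured compounds named here, the one measured single-place step, no change at the digits printed from compound 1 to compound 2 (within the scatter), alters the same phenyl ring and is flat within the scatter. Compound 4 `Cc1ccccc1-c1nc2cn(-c3cccc(C#N)c3)nc2c(=O)n1CC1CCCN(C(C)C)C1` differs from compound 2 by cyano in place of methoxy on an aromatic carbon. Going by the values given here, no measured step tests this exchange directly, and the only step on that ring is flat, so compound 4 is expected to show no change beyond the scatter, a number 0.10 log units lower from compound 2 to compound 4 (within the scatter). Compound 4 is therefore estimated at 9.9, between 9.4 and 10.3.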

Compound 4, acid dissociation constant: 9.9
The estimate for compound 4 equals the measured number at the digits printed, within the range that was stated.
By their numbers in this assay, from the lowest: compound 3; then compounds 4, 1 and 2 (each within the scatter of the next).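

In this assay, cyano in place of methoxy on this aromatic carbon gives a number 0.10 log units lower from compound 2 to compound 4 (within the scatter), and 3-cyanophenyl in place of 4-methoxyphenyl gives a number 0.10 log units lower from compound 1 to compound 4 (within the scatter). The earlier step had changed only where methoxy sits, whereas these steps show that a different group on this ring also stays within the scatter. Nothing available bears on why this is so. From the compounds shown here alone, whether an amine or a carboxylic acid on this ring would also stay within the scatter remains open. So does which single-place change separates compound 3 from the others.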